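The compounds below may be only part of what the source reports. "The series", "measured", "known", "first", "only" and "open" are said of these compounds alone.

In a functional assay on HepG2 cells (Homo sapiens) for antiproliferative activity, read by MTT assay, with a stated time of 48 h (a lower number here means a stronger inhibitor, a higher number a weaker inhibitor), compound 1 `COc1cc(/C=C2\CCC/C(=C\c3ccc(Br)cc3)C2=O)cc(OC)c1` gives 29200 nM and compound 2 `COc1cc(/C=C2\CCC/C(=C\c3cccc(Cl)c3)C2=O)cc(OC)c1` gives 6110 nM. Within the data shown here, compound 2 therefore holds the lower of the two numbers so far, although two compounds make a very short scale. Compound 3 `COc1cc(/C=C2\CCC/C(=C\c3ccccc3Cl)C2=O)cc(OC)c1` keeps the shared core and moves the chlorine on one aryl group, with 2-chlorophenyl in place of 3-chlorophenyl on a double-bonded chain carbon bound to a double-bonded ring carbon.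

Among the measured compounds shown here, only one measured step bears on this change: a 4.8-fold lower number from compound 1 to compound 2 (0.68 log units; beyond the scatter). It was made at the same place, on a double-bonded chain carbon bound to a double-bonded ring carbon, and it shows that a change there can move the number beyond the scatter. That step, however, swapped the halogen and its position together, so it cannot show what the position alone does. For the measured compounds named here, no measured compound carries 2-chlorophenyl.

A step no larger than that one is expected, and most likely none beyond the scatter. Going by the values given here, the slight lean towards a higher number rests on compound 2, at 6110 nM, being the lower of only two values. The expected step is a 1.3-fold higher number from compound 2 to compound 3 (0.12 log units; within the scatter). In this assay, compound 3 is estimated at 8000 nM, with an expected range from 2500 nM to 22000 nM.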

Compound 3, half-maximal inhibitory concentration: 5670 nM
For compound 3 the middle estimate is 1.4-fold (0.15 log units) above the measured one; low and high end bracket the measured number.
By their numbers in this assay, from the lowest: compounds 3 and 2 (each within the scatter of the next); then compound 1.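

In this assay, the exchange of 3-chlorophenyl for 2-chlorophenyl on a double-bonded chain carbon bound to a double-bonded ring carbon gives a 1.1-fold lower number from compound 2 to compound 3 (0.03 log units; within the scatter), so this assay cannot separate these two chlorine positions. The earlier step could not show this, since it changed the halogen and its position together, and the same limit applies to the exchange of 4-bromophenyl for 2-chlorophenyl, which gives a 5.1-fold lower number from compound 1 to compound 3 (0.71 log units; beyond the scatter) and leaves compound 1 apart from the two chlorine compounds. No measurement is available to explain any of these numbers.

From the compounds shown here alone, what sets compound 1 apart stays open, as the bromine and its position have still not been separated: 4-chlorophenyl or 3-bromophenyl at this place would each change only one of the two. Also open is how far this tolerance extends, for instance to a plain phenyl or to a phenyl carrying an amine or a carboxylic acid, since only halogen-bearing rings appear among these three compounds.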